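The compounds below may be only part of what the source reports. "The series", "measured", "known", "first", "only" and "open" are said of these compounds alone.

Values in a functional assay on cells (Homo sapiens) for cytotoxicity, read by MTT assay, with a stated time of 24 h (a higher number here means a weaker inhibitor, a lower number a stronger inhibitor), follow
Compound 1 `CCCCCCCCCCCCCCNC(=O)[C@H](CO)/N=C/c1cccc(C)c1` gives 82900 nM
Compound 2 `CCCCCCCCCCCCCCNC(=O)[C@H](CO)/N=C/c1cccc(OC)c1` gives 31300 nM
Compound 3 `CCCCCCCCCCCCCCNC(=O)[C@H](CO)/N=C/c1ccccc1OC` gives 12500 nM

Compound 3 holds the lowest number of the three at 12500 nM in this assay, and its gaps to both other compounds lie beyond the scatter. The next compound, compound 4 `CCCCCCCCCCCCCCNC(=O)[C@H](CO)/N=C/c1ccccc1Cl`, has not yet been measured. It differs from compound 3 by one change on an aromatic carbon, ortho to a large group: chloro in place of methoxy (chloro in place of methoxy on an aromatic carbon), which turns 2-methoxyphenyl into 2-chlorophenyl.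

Going by the values given here, no measured compound carries chloro, so no step reads on this change directly. The nearest evidence concerns the methoxy group. Placing methoxy in place of methyl gave a 2.6-fold lower number from compound 1 to compound 2 (0.42 log units; beyond the scatter), and 2-methoxyphenyl in place of 3-methoxyphenyl gave a 2.5-fold lower number from compound 2 to compound 3 (0.40 log units; beyond the scatter). The largest step in the set, a 6.6-fold lower number from compound 1 to compound 3 (0.82 log units; beyond the scatter), is also modest. A modest step is therefore expected here too. Since compound 3 reached its low number through the methoxy steps, such as a 2.5-fold lower number from compound 2 to compound 3 (0.40 log units; beyond the scatter), losing that group is expected to raise the number slightly, though a move the other way cannot be excluded. The expected step is a 1.4-fold higher number from compound 3 to compound 4 (0.16 log units; within the scatter) as an estimate. For compound 4 the estimated value is 18000 nM, with an expected range from 7000 nM to 45000 nM.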

Compound 4, half-maximal inhibitory concentration: 10300 nM
For compound 4 the middle estimate is 1.7-fold (0.24 log units) above the measured one, and the stated range covers the measured number.
By their numbers in this assay, from the lowest: compounds 4 and 3 (each within the scatter of the next); then compound 2; then compound 1.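

In this assay, chloro in place of methoxy on an aromatic carbon, ortho to a large group, gives a 1.2-fold lower number from compound 3 to compound 4 (0.08 log units; within the scatter) and so stays within the scatter: at this place the methoxy group, with its hydrogen-bond acceptor, can be replaced by a group without one and the number holds. The low number is therefore not tied to methoxy, as compound 3 alone could have suggested, and the 2-chlorophenyl group keeps clear gaps to the other two compounds, with a 3.0-fold lower number from compound 2 to compound 4 (0.48 log units; beyond the scatter) and with an 8.0-fold lower number from compound 1 to compound 4 (0.91 log units; beyond the scatter) as well. Both of those steps change the group and its place on the ring together, so neither separates the two, and no measurement shown here accounts for the match between chloro and methoxy.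

The compounds shown leave open whether chloro would give a similar number at the place that methyl and methoxy occupy in compound 1 and compound 2. They also leave open how an amine or a carboxylic acid on this same aromatic carbon would read, and whether a shorter chain on the amide would alter the picture.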